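From butyl to methyl on a piperazine side chain

The source may report more compounds than this note shows. Statements on the series, on what has been measured and on what is new or still open speak of the compounds shown alone.

Measured in a functional assay on A-375 cells (Homo sapiens) for cytotoxicity, read by MTT assay, with a stated time of 72 h; a higher number here means a weaker inhibitor, a lower number a stronger inhibitor:
- compound 1 `CN(C)CCCCCn1c2c(c3ccccc31)C(=O)c1c[n+]([O-])c3ccccc3c1C2=O`: 560 nM
- compound 2 `O=C1c2c[n+]([O-])c3ccccc3c2C(=O)c2c1c1ccccc1n2Cc1cn(C[C@H](O)CO)nn1`: 350 nM
- compound 3 `CCCCN1CCN(CCCCn2c3c(c4ccccc42)C(=O)c2c[n+]([O-])c4ccccc4c2C3=O)CC1`: 2150 nM

The highest of these three numbers belongs to compound 3. The step leading there is a 3.8-fold higher number from compound 1 to compound 3 (0.58 log units; beyond the scatter). The other measured step, a 1.6-fold lower number from compound 1 to compound 2 (0.20 log units; within the scatter), brings in no piperazine and bears less on what follows.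

Compound 4 `CN1CCN(CCCn2c3c(c4ccccc42)C(=O)c2c[n+]([O-])c4ccccc4c2C3=O)CC1` has not yet been measured. It differs from compound 3 as follows: 4-methylpiperazin-1-yl in place of (4-butylpiperazin-1-yl)methyl on a saturated chain carbon, three bonds along the chain from an aromatic nitrogen. The piperazine ring stays, so only part of the earlier rise is expected to be undone. The expected change in this assay is modest and towards a lower number: a 2.2-fold lower number from compound 3 to compound 4 (0.33 log units; beyond the scatter). Compound 4 is estimated at 1000 nM, with an expected range of 350 nM to 2800 nM.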

Compound 4, half-maximal inhibitory concentration: 470 nM
Compound 4: the middle estimate sits 2.1-fold (0.33 log units) above what was measured; the range from low to high includes it.
By their numbers in this assay, from the lowest: compounds 2, 4 and 1 (each within the scatter of the next); then compound 3.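

In this assay, a 4.6-fold lower number from compound 3 to compound 4 (0.66 log units; beyond the scatter) shows that the piperazine ring need not bring a high number, although the ring substituent and the chain carrying it change together. Compound 4 falls in with the non-piperazine compounds, with a 1.2-fold lower number from compound 1 to compound 4 (0.08 log units; within the scatter) and a 1.3-fold higher number from compound 2 to compound 4 (0.13 log units; within the scatter) both within the scatter. No available evidence explains this step.

Which of the two changes matters stays open; a 4-butylpiperazin-1-yl group on the shorter chain would separate them. As far as these compounds go, how a morpholine in place of the piperazine would read also remains open.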